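This account rests on a few compounds, and the source may have more. Where it says the series, first, only, none or still open, it means among the compounds named here.

Of the compounds shown here, three sharing one core have been measured in an ADME assay on microsomes from liver (Homo sapiens) for metabolic stability, tested at 2.5 uM; on this read-out higher numbers stand for fast clearance and lower numbers for slow clearance. Compound 1 `COc1ccc(-c2c(S(=O)(=O)c3cc(F)cc(F)c3)cnc3c(F)cccc23)cc1` gives 2.59 mL/min in this assay. Compound 2 `COc1ccc(-c2c(S(=O)(=O)c3ccc(C)c(F)c3)cnc3c(F)cccc23)cc1` gives 3.27 mL/min, and compound 3 `COc1ccc(-c2c(S(=O)(=O)c3ccc(OC)cc3)cnc3c(F)cccc23)cc1` gives 2.12 mL/min. Compound 2 stands highest of the three numbers, yet its gaps to both neighbours are within the scatter: the step is a 1.3-fold higher number from compound 1 to compound 2 (0.10 log units; within the scatter), and a 1.5-fold lower number from compound 2 to compound 3 (0.19 log units; within the scatter). The remaining step, a 1.2-fold lower number from compound 1 to compound 3 (0.09 log units; within the scatter), is likewise within the scatter.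

Compound 4 `Cc1ccc(S(=O)(=O)c2cnc3c(F)cccc3c2-c2ccc(F)cc2)cc1F` has not yet been measured in this assay. Its difference from compound 2 is fluoro in place of methoxy on an aromatic carbon. The three measured steps all change the group on the sulfonyl sulfur, not the aromatic carbon where this change sits, so none of them bears directly on it; they only show that a swap of one aromatic group for another left this assay unchanged beyond the scatter in every measured case. On that basis, a step of no more than the scatter is expected from compound 2 to compound 4, namely a 1.1-fold lower number from compound 2 to compound 4 (0.04 log units; within the scatter). Compound 4 is therefore estimated at 3 mL/min in this assay, with a range from 1.7 mL/min to 5.3 mL/min.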

Compound 4, intrinsic clearance in a liver preparation (reported as CLH), per the amount of preparation that the assay uses: 2.75 mL/min
For compound 4 the middle estimate is 1.1-fold (0.04 log units) above the measured one; the range from low to high includes it.
By their numbers in this assay, from the lowest: compounds 3, 1, 4 and 2 (each within the scatter of the next).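

Moving away from the sulfonyl sulfur for the first time, the swap of 4-methoxyphenyl for 4-fluorophenyl gives a 1.2-fold lower number from compound 2 to compound 4 (0.08 log units; within the scatter) in this assay, so compound 2 and compound 4 cannot be told apart on this read-out. Among the compounds shown here, this is the first direct reading at this aromatic carbon, para to a large group, and it shows that methoxy, with its hydrogen-bond acceptor, can give way to fluoro, which has none, without a step beyond the scatter. No measurement shown here accounts for this result.

For the compounds shown here, the change is seen only with 3-fluoro-4-methylphenyl on the sulfonyl sulfur, so it remains open whether it would read the same with 3,5-difluorophenyl or 4-methoxyphenyl there. Methoxy and fluoro are also the only groups shown at this position, which leaves open how an amine, a carboxylic acid or a longer chain such as butoxy would behave in its place.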